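Working notes: chloro in place of hydrogen, compound 4

The source may report more compounds than this note shows. Statements on the series, on what has been measured and on what is new or still open speak of the compounds shown alone.

Within the data shown here, in a functional assay on HepG2 cells (Homo sapiens) for cytotoxicity, read by MTT assay, with a stated time of 48 h (a lower number here means a stronger inhibitor, a higher number a weaker inhibitor), compound 3 (`CC1=NN(C(=O)CN2CCCCC2)C(c2ccccc2O)C1`) gives 3020 nM as the lowest of the two numbers so far, and compound 1 (`CC1=NN(C(=O)c2ccc(C)cc2)C(c2ccccc2O)C1`) gives 11300 nM as the other. Compound 2 (`CC1=NN(S(=O)(=O)c2ccc([N+](=O)[O-])cc2)C(c2cc(Cl)ccc2O)C1`) stands as "not active" (no number reported) without a number. Compound 4 (`CC1=NN(C(=O)CN2CCC(Cl)CC2)C(c2ccccc2O)C1`) differs from compound 3 in one place, piperidin-1-yl to 4-chloropiperidin-1-yl, that is chloro in place of hydrogen on a saturated ring carbon. Among the measured compounds shown here, one measured step bears on this, and only loosely: a 3.7-fold lower number from compound 1 to compound 3 (0.57 log units; beyond the scatter) stands as a modest change beyond the scatter, with (piperidin-1-yl)methyl in place of 4-methylphenyl on a carbonyl carbon. That step exchanges a whole group. For the measured compounds named here, no measured pair tests a substituent on the saturated ring. No step beyond the scatter is expected in this assay and no direction is favoured. For compound 4 the estimated value is 3000 nM with an expected range from 1100 nM to 8000 nM as its ends. This expectation amounts to a 1.0-fold lower number from compound 3 to compound 4 (0.00 log units; within the scatter) as the estimated step.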

Compound 4, half-maximal inhibitory concentration: 42100 nM
Compound 4: middle estimate off by 14-fold (1.15 log units), on the low side, outside the stated range (above it).
By their numbers in this assay, from the lowest: compound 3; then compound 1; then compound 4.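

In this assay, the saturated ring carbon three ring bonds from the ring nitrogen proves sensitive to substitution: chloro in place of hydrogen gives a 14-fold higher number from compound 3 to compound 4 (1.14 log units; beyond the scatter), a large step from a single added heavy atom. This step runs opposite in direction to the earlier exchange of a whole group, a 3.7-fold lower number from compound 1 to compound 3 (0.57 log units; beyond the scatter), and is the larger of the two, so the gain seen with the piperidin-1-yl group does not survive this substitution on its ring. No measurement at hand gives a cause for the step.

Going by these compounds, whether a methyl or hydroxyl group on this ring carbon would follow chloro remains open. Also open, on these data alone, is whether the same step would appear with chloro on another carbon of the ring, or with an amine at this place.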